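Two Aziridinyl Quinones Measured, a Benzyl Analogue Estimated

The compounds below may be only part of what the source reports. "The series", "measured", "known", "first", "only" and "open" are said of these compounds alone.

Measured so far:
compound 1, `CC1=C(N2CC2)C(=O)C(CCC(=O)N(C)C)=C(N2CC2)C1=O`: 5.09
compound 2, `CC(C)C1=C(N2CC2)C(=O)C=C(N2CC2)C1=O`: 5.16

Both compounds were tested in a functional assay on L1210 cells (Mus musculus), with a stated time of 1 days; a higher number here means a more potent compound, by a factor of ten per unit of this negative logarithm, a lower number a less potent compound. In this assay compound 1 gives 5.09, while compound 2 gives 5.16; the two numbers lie within the scatter of each other, so neither can be called stronger than the other. For the measured compounds named here, no step between compounds differing in one place is available here.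

Compound 3, `CC1=C(N2CC2)C(=O)C(Cc2ccccc2)=C(N2CC2)C1=O`, has not yet been measured. It differs from compound 1 as follows: phenyl in place of (dimethylcarbamoyl)methyl on a saturated chain carbon bound to a double-bonded ring carbon. Going by the values given here, with no measured step of this kind to lean on, only a loose expectation is possible. Compound 3 is expected to come out near 5.35 in this assay, which means an expected step of a number 0.26 log units higher from compound 1 to compound 3 (within the scatter); the estimate ranges from 4.85 to 5.95, so no change beyond the scatter is excluded.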

Compound 3, logarithm of the reciprocal of the active concentration, log(1/C): 4.74
Beside the measured number, compound 3's estimate is 0.61 log units above it, outside the stated range (below it).
By their numbers in this assay, from the lowest: compound 3; then compounds 1 and 2 (each within the scatter of the next).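

Exchanging 2-(dimethylcarbamoyl)ethyl for benzyl on the shared core gives a number 0.35 log units lower from compound 1 to compound 3 (beyond the scatter) in this assay, so the group carried at this place can change the number. The change does not alter the heavy-atom count of the exchanged part: (dimethylcarbamoyl)methyl, with its hydrogen-bond acceptor, gives way to phenyl, an aromatic ring of carbon only, with no acceptor. Nothing measured here explains why the number falls.

The compounds shown do not separate the loss of the amide from the arrival of the aromatic ring. A plain propyl chain at the same place would speak to that question, while a chain ending in a carboxylic acid or an amine, or a benzyl group bearing a methoxy substituent, would show how far this place tolerates other groups.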